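Cyclopropylsulfonyl Replaces Acetyl on a Shared Core

A few compounds are considered here, and "the series" means these few. Any claim that something is new, unique, unknown or untested is made for them only; others in the source may bear on it.

Of the compounds shown here, three have been tested in a functional assay on Urethra with Alpha-1A adrenergic receptor (Oryctolagus cuniculus) as the target; on this read-out higher numbers stand for larger maximal responses and lower numbers for smaller maximal responses. Compound 1 `CC(c1cccc(NS(C)(=O)=O)c1)c1c[nH]cn1` gives 92%, compound 2 `CS(=O)(=O)Nc1ccc(Cl)c2c1CCCC2c1c[nH]cn1` gives 41%, and compound 3 `CC(=O)Nc1cccc2c1CCCC2c1c[nH]cn1` gives 70%. Compound 3 stands second highest of the three, beyond the scatter below compound 1 and beyond the scatter above compound 2. Compound 4 `O=S(=O)(Nc1cccc2c1CCCC2c1c[nH]cn1)C1CC1` has not yet been measured. Compound 4 differs from compound 3 by cyclopropylsulfonyl in place of acetyl on a nitrogen on an aromatic ring. Among the compounds with values here, no measured pair isolates this change. As far as these compounds go, the two compounds carrying a sulfonyl group on that nitrogen, compound 1 with 92% and compound 2 with 41%, lie on both sides of compound 3, so the direction stays open. A small upward step is expected, a number 5 percentage points higher from compound 3 to compound 4 (within the scatter), within the scatter. For compound 4 an efficacy of 75% is estimated, between 50% and 95%.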

Compound 4, largest response reached (reported as efficacy), in percent of the reference or control that the assay uses: 51%
For compound 4 the middle estimate is 24 percentage points above the measured one, within the range that was stated.
By their numbers in this assay, from the lowest: compounds 2 and 4 (each within the scatter of the next); then compound 3; then compound 1.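

In this assay the exchange of acetyl for cyclopropylsulfonyl on a nitrogen on an aromatic ring gives a number 19 percentage points lower from compound 3 to compound 4 (beyond the scatter) on the shared core. Within the data shown here, this is the first direct reading of this change, and it settles for this pair the direction the earlier compounds left open. No measurement shown offers an explanation for the step.

As far as these compounds go, whether the step follows the sulfonyl or the cyclopropyl stays open. Cyclopropylcarbonyl or ethylsulfonyl on the same nitrogen would separate the two.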